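Swapping trifluoromethyl for nitro on a crown-ether quinazoline

The source may hold more compounds than are shown below. What is called first, only, known or untested is meant among the compounds shown, and "the series" means these compounds.

Measured so far:
- compound 1, `FC(F)(F)c1ccc(COc2cccc(Nc3ncnc4cc5c(cc34)OCCOCCOCCO5)c2)cc1`: 34000 nM
- compound 2, `FC(F)(F)c1ccc(COc2ccc(Nc3ncnc4cc5c(cc34)OCCOCCOCCOCCO5)cc2)cc1`: 3340 nM
- compound 3, `c1ccc(COc2cccc(Nc3ncnc4cc5c(cc34)OCCOCCO5)c2)cc1`: a limit, > 100000 nM

Of the compounds shown here, three share the same core and have been tested in a functional assay on HepG2 cells (Homo sapiens) for antiproliferative activity, read by MTT assay, with a stated time of 72 h; on this read-out higher numbers stand for weaker inhibition and lower numbers for stronger inhibition. Compound 2 gives 3340 nM, the lowest of the two numbers obtained. Compound 1 gives 34000 nM, a higher number that lies beyond the scatter of the method. For compound 3 only a limit was reached, (the limit of > 100000 nM in this assay, at which 1 of the 3 values shown sits), so it stands apart from the numbers.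

The next compound, compound 4, `O=[N+]([O-])c1ccc(COc2ccc(Nc3ncnc4cc5c(cc34)OCCOCCOCCOCCO5)cc2)cc1`, is compound 2 with one change: nitro in place of trifluoromethyl on an aromatic carbon. Within the data shown here, no measured pair in this set shows this exact swap, so there is no step to copy. Both groups are small and uncharged, and the rest of the molecule stays the same, so the step from compound 2 to compound 4 is expected to stay within the usual scatter, with a slight lean toward a weaker result, a 1.3-fold higher number from compound 2 to compound 4 (0.13 log units; within the scatter). On that basis compound 4 is estimated at 4500 nM in this assay, with a range from 1500 nM to 14000 nM.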

Compound 4, half-maximal inhibitory concentration: > 100000 nM
Compound 4 was reported as a limit; the forecaster's own chance of this, stated with the estimate: 5%; middle value at least 22-fold (1.34 log units) away from the limit.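

Exchanging trifluoromethyl for nitro on an aromatic carbon, para to a large group, gives an at least 29-fold higher number from compound 2 to compound 4 (1.47 log units; beyond the scatter) in this assay and so turns a measurable result into none. Among these compounds, this is the first pair here that differs in one place only, so it gives the first direct sign that the group at this position matters and that two small, uncharged groups cannot be treated as interchangeable there. In this assay compound 4 gives > 100000 nM, which is a limit and not a number, so the step has a lower bound but no known full size: the limit of > 100000 nM in this assay, at which 2 of the 4 values shown sit.

Whether the loss is particular to nitro stays open, since only these two groups are shown at this position, and a nitrile, an amine or a carboxylic acid there could land near compound 2 or at the limit. The data do not show what lies behind the loss. They also do not show whether the same swap would have a similar effect on the core of compound 1.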